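A Second Methoxy Group on a Cell-Growth Inhibitor

A few compounds are considered here, and "the series" means these few. Any claim that something is new, unique, unknown or untested is made for them only; others in the source may bear on it.

Of the compounds shown here, three have been tested in a functional assay on MCF7 cells (Homo sapiens) for cytotoxicity, read by sulforhodamine B assay, with a stated time of 48 h; a higher number here means a weaker inhibitor of growth, a lower number a stronger inhibitor of growth. Compound 1, `CCOC(=O)c1[nH]c2ccccc2c1C(=O)c1cc(OC)c(OC)c(OC)c1N`, gives 480 nM in this assay. Compound 2, `CCOC(=O)c1[nH]c2ccc(OC)cc2c1C(=O)c1cc(OC)c(OC)c(OC)c1N`, carries one more group on the same core, and in this assay compound 2 gives 540 nM. Compound 3, `COc1ccc2c(Cc3cc(OC)c(OC)c(OC)c3N)c[nH]c2c1`, is built on a different core, and in this assay compound 3 gives 1830 nM, the highest of the three numbers. The difference between the core of compound 1 and the core of compound 3 is not broken down here.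

The change from compound 1 to compound 2 is methoxy in place of hydrogen on an aromatic carbon. It produced a 1.1-fold higher number from compound 1 to compound 2 (0.05 log units; within the scatter), so the added group left growth inhibition essentially unchanged.

Compound 4, `COc1cc2[nH]cc(Cc3cc(OC)c(OC)c(OC)c3N)c2cc1OC`, has not yet been measured. It differs from compound 3 by methoxy in place of hydrogen on an aromatic carbon. Within the data shown here, this is the same kind of change as the one between compound 1 and compound 2, though not the same: in compound 4 the entering group sits ortho to a methoxy group (2 heavy atoms), whereas at the place in compound 2 no such group is counted.

Compound 4 is therefore expected to show the step of a 1.1-fold higher number from compound 3 to compound 4 (0.04 log units; within the scatter), because a 1.1-fold higher number from compound 1 to compound 2 (0.05 log units; within the scatter) stayed within the scatter. In this assay compound 4 is estimated at 2000 nM, most likely falling between 900 nM and 4500 nM. Among the measured compounds shown here, the single earlier example of this kind of change is a thin basis, so the range is kept wide.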

Compound 4, concentration for 50% growth inhibition: "not active" (no number reported)
No number was reported for compound 4; there is nothing to compare the estimate with.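

In this assay, among these compounds, compound 4 is reported as "not active" with no number, so no step from compound 3 to compound 4 can be read. Nothing in the data shown speaks to this result. The compounds shown leave open how much the methoxy group entering ortho to a methoxy group changes growth inhibition on this core.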